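Aminopyrazole Growth Inhibitors: Exchanging the N-Aryl Halogen

A few compounds are considered here, and "the series" means these few. Any claim that something is new, unique, unknown or untested is made for them only; others in the source may bear on it.

compound 1 `Cc1ccc(-c2cc(N)n(-c3ccc(Br)cc3)n2)cc1`: 54300 nM
compound 2 `Cc1ccc(-c2nn(-c3cccc(Cl)c3)c(N)c2C=O)cc1`: 71800 nM

In a functional assay on NCI-H226 cells (Homo sapiens) for inhibition, read by MTT assay, with a stated time of 72 h (a higher number here means a weaker inhibitor of growth, a lower number a stronger inhibitor of growth), compound 2 gives 71800 nM, the top of the two numbers, though compound 1 with 54300 nM sits within the scatter of it. Compound 3 `Cc1ccc(-c2nn(-c3ccc(Br)cc3)c(N)c2C=O)cc1` differs from compound 2 in one place: 4-bromophenyl in place of 3-chlorophenyl on an aromatic nitrogen. Within the data shown here, no pair of measured compounds isolates this change, so no step beyond the scatter is expected in either direction; compound 1 also carries 4-bromophenyl and in this assay stays close to compound 2. Compound 3 is therefore estimated at 65000 nM, with a range from 25000 nM to 170000 nM. The expected step is a 1.1-fold lower number from compound 2 to compound 3 (0.04 log units; within the scatter).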

Compound 3, concentration for 50% growth inhibition: 8500 nM
Estimate against measurement, compound 3: 7.6-fold (0.88 log units) above, outside the stated range (below it).
By their numbers in this assay, from the lowest: compound 3; then compounds 1 and 2 (each within the scatter of the next).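

In this assay, the group on the aromatic nitrogen proves to matter when the formyl group is present: 4-bromophenyl in place of 3-chlorophenyl gives an 8.4-fold lower number from compound 2 to compound 3 (0.93 log units; beyond the scatter). Among these compounds, with 4-bromophenyl kept, formyl in place of hydrogen on the aromatic carbon gives a 6.4-fold lower number from compound 1 to compound 3 (0.81 log units; beyond the scatter), a second step that the earlier compounds could not show. No measurement is at hand that bears on what lies behind either step. The compounds shown leave open whether the halogen itself or its place on the phenyl ring carries the first step, which 4-chlorophenyl or 3-bromophenyl would separate. They also leave open how a carboxylic acid in place of the formyl group would read.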